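This account rests on a few compounds, and the source may have more. Where it says the series, first, only, none or still open, it means among the compounds named here.

Measured in a physicochemical assay for solubility, read by HPLC, in phosphate buffer, measured as kinetic solubility, at pH 7.4; a higher number here means a more soluble compound, a lower number a less soluble compound:
compound 1 `CCC(=O)c1cc(-c2ccc(S(N)(=O)=O)cc2)n(-c2ccc(Cl)cc2)n1`: 41900 nM
compound 2 `CC(C)(C)C(=O)c1cc(-c2ccc(S(N)(=O)=O)cc2)n(-c2ccc(Cl)cc2)n1`: 6600 nM
compound 3 `NS(=O)(=O)c1ccc(-c2cc(C(=O)CC3CCC3)nn2-c2ccc(Cl)cc2)cc1`: 4300 nM

Compound 3 gives 4300 nM, and the gap to compound 2 is small: a 1.5-fold lower number from compound 2 to compound 3 (0.19 log units; within the scatter). Compound 1 stands apart from both, with a 6.3-fold lower number from compound 1 to compound 2 (0.80 log units; beyond the scatter) and a 9.7-fold lower number from compound 1 to compound 3 (0.99 log units; beyond the scatter).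

Compound 4 `NS(=O)(=O)c1ccc(-c2cc(C(=O)NC3CC3)nn2-c2ccc(Cl)cc2)cc1` carries cyclopropylamino in place of cyclobutylmethyl on a carbonyl carbon. Among the measured compounds shown here, no measured compound holds this group, so the measured steps bear on the change only indirectly. They do show that exchanges on this carbonyl carbon can reach a modest size, as in a 9.7-fold lower number from compound 1 to compound 3 (0.99 log units; beyond the scatter). The direction is less secure and rests on a single compound: compound 1, with its ethyl, gives 41900 nM. A modest move towards a higher number is therefore expected, with a return to the level of compound 3 still possible. The estimated step is a 3.5-fold higher number from compound 3 to compound 4 (0.54 log units; beyond the scatter). For compound 4 the expected value is 15000 nM, with an estimated range of 4000 nM to 50000 nM.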

Compound 4, solubility: 72600 nM
Estimate against measurement, compound 4: 4.8-fold (0.68 log units) below; measured number above the stated range.
By their numbers in this assay, from the lowest: compounds 3 and 2 (each within the scatter of the next); then compounds 1 and 4 (each within the scatter of the next).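

In this assay the exchange on this carbonyl carbon proves able to raise the number by a large step as well as lower it (a 17-fold higher number from compound 3 to compound 4 (1.23 log units; beyond the scatter)) and (an 11-fold higher number from compound 2 to compound 4 (1.04 log units; beyond the scatter)). The high level seen with ethyl therefore no longer rests on one compound: cyclopropylamino, with its nitrogen and hydrogen-bond donor, gives a number that cannot be told apart from the ethyl compound (a 1.7-fold higher number from compound 1 to compound 4 (0.24 log units; within the scatter)). Nothing available accounts for the size of these steps.

The compounds shown leave open whether the high number goes with the nitrogen, the three-membered ring or neither. A cyclopropylmethyl group and an ethylamino group on the same carbonyl carbon would separate these, as each keeps one feature of cyclopropylamino without the other.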